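This account rests on a few compounds, and the source may have more. Where it says the series, first, only, none or still open, it means among the compounds named here.

Measured compounds in a functional assay on C6 cells (Rattus norvegicus) for cytotoxicity, read by MTT assay, with a stated time of 24 h, tested at 50 ug/mL; on this read-out higher numbers stand for a weaker effect at the one concentration tested and lower numbers for a stronger effect:
compound 1 `O=C(CSc1ncccn1)N/N=c1/scc(-c2ccc(Br)cc2)n1-c1ccccc1` — 69%
compound 2 `O=C(CSc1ncccn1)N/N=c1/scc(-c2ccc(F)cc2)n1-c1ccccc1` — 55.5%

Compound 2 stands lowest of the two numbers; compound 1 gives 69%, and the step of a number 13.5 percentage points lower from compound 1 to compound 2 (beyond the scatter) concerns the group on the aromatic carbon only. Compound 3 `Cc1nnc(SCC(=O)N/N=c2/scc(-c3ccc(F)cc3)n2-c2ccccc2)s1` differs from compound 2 by 5-methyl-1,3,4-thiadiazol-2-yl in place of pyrimidin-2-yl on a sulfur. Within the data shown here, no measured step changes the group on this sulfur, so the one known step does not bear on it, and no step beyond the scatter is expected in this assay. The estimate for compound 3 is 55%, range 35% to 75%, which is expected to mean a number 0.5 percentage points lower from compound 2 to compound 3 (within the scatter).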

Compound 3, a percentage reported as activity, at one concentration (the size of the read-out at that concentration, not a potency): 37.4%
Estimate against measurement, compound 3: 17.6 percentage points above, and the stated range covers the measured number.
By their numbers in this assay, from the lowest: compound 3; then compound 2; then compound 1.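

The group on the sulfur is not a silent position: 5-methyl-1,3,4-thiadiazol-2-yl in place of pyrimidin-2-yl gives a number 18.1 percentage points lower from compound 2 to compound 3 (beyond the scatter) in this assay. Both groups carry the same number of heavy atoms, so the step arises without a change in that count. Nothing measured on these compounds accounts for the step.

Open, going by these compounds, is whether the same exchange on the sulfur gives a similar step with bromo in place of fluoro on the aromatic carbon. Also open, on these data alone, is whether the methyl matters, which 1,3,4-thiadiazol-2-yl without it, or a plain phenyl on this sulfur, would address.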